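This account rests on a few compounds, and the source may have more. Where it says the series, first, only, none or still open, it means among the compounds named here.

In a toxicity assay on THP-1 cells (Homo sapiens) for inhibition (on this read-out lower numbers stand for higher toxicity in this test and higher numbers for lower toxicity in this test), compound 1 `Cn1c(-c2ccccc2)cnc1NC(=O)c1ccccc1` gives > 100000 nM, which is a limit of the test rather than a number. Compound 2 `Cc1ccccc1-c1cnc(NC(=O)c2ccc(F)cc2)n1C` also reaches only a limit in this assay, > 50000 nM. Compound 3 `COc1ccc(-c2cnc(NC(=O)c3ccccn3)n2C)cc1` stops at a limit in this assay as well, > 100000 nM. So every value shown is a limit: the limit of > 100000 nM in this assay, at which 2 of the 3 values shown sit, and (the limit of > 50000 nM in this assay, at which 1 of the 3 values shown sits). Compound 3 therefore stands alongside the other two, and no order among the three can be read from these figures.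

Compound 4 `COc1ccc(-c2cnc(NC(=O)c3ccc(O)cc3)n2C)cc1` differs from compound 3 in one place: 4-hydroxyphenyl in place of pyridin-2-yl on a carbonyl carbon. Among the measured compounds shown here, no step between measured compounds exists in this assay, so the effect of the change can only be expected. The expectation is that the step from compound 3 to compound 4 stays within the scatter, a number no higher from compound 3 to compound 4 (the limit leaves the size open), with compound 4 most likely again reported only as a limit. Compound 4 is thus estimated at 100000 nM in this assay, with a range from 40000 nM to 300000 nM.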

Compound 4, half-maximal cytotoxic concentration: > 100000 nM
Compound 4 gave a limit, no number (the forecaster's own chance of this, stated with the estimate: 80%); the middle value sits exactly at the limit.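

Among the compounds shown here, compound 3 and compound 4 both stop at a limit in this assay, so no step between them can be read. The compounds shown leave open whether 4-hydroxyphenyl and pyridin-2-yl on a carbonyl carbon differ at all in this assay, as none of them gives a number.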